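Cytotoxicity notes: from compound 2 to compound 4

The source may hold more compounds than are shown below. What is called first, only, known or untested is meant among the compounds shown, and "the series" means these compounds.

Of the compounds shown here, three on a shared core have been measured: compound 1 `Cc1cc(=O)oc2cc(OS(=O)(=O)C(F)(F)F)c(OS(=O)(=O)C(F)(F)F)cc12`, compound 2 `Cc1cc(C)cc(-c2cc3oc(=O)cc(C)c3cc2OS(=O)(=O)C(F)(F)F)c1` and compound 3 `Cc1cc(=O)oc2cc(-c3ccc(C(F)(F)F)cc3)c(OS(=O)(=O)C(F)(F)F)cc12`. In a toxicity assay on MT4 cells (Homo sapiens) for cytotoxicity, read by MTT assay, with a stated time of 5 days (a higher number here means that more compound is tolerated, a lower number that less compound is tolerated), compound 1 gives 43.5 ug/mL, compound 2 gives 33.1 ug/mL and compound 3 gives 80.3 ug/mL. Compound 2 sits at the low end of these numbers, with a 1.3-fold lower number from compound 1 to compound 2 (0.12 log units; within the scatter) and a 2.4-fold higher number from compound 2 to compound 3 (0.38 log units; beyond the scatter).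

Compound 4 `Cc1cccc(-c2cc3oc(=O)cc(C)c3cc2OS(=O)(=O)C(F)(F)F)c1` differs from compound 2 by one change: hydrogen in place of methyl on an aromatic carbon. In words, this is hydrogen in place of methyl on an aromatic carbon, turning 3,5-dimethylphenyl into 3-methylphenyl.

Among the compounds with values here, no measured step removes a single methyl. The closest evidence is the exchange of the whole aryl group, a 2.4-fold higher number from compound 2 to compound 3 (0.38 log units; beyond the scatter), a modest step. The step of a 1.8-fold higher number from compound 1 to compound 3 (0.27 log units; within the scatter) also replaces a whole group and stays within the scatter. One methyl is a smaller change than either, so no step beyond the scatter is expected in this assay, and no clear direction is expected. The expected result is a 1.1-fold higher number from compound 2 to compound 4 (0.04 log units; within the scatter). For compound 4 the estimate is 36 ug/mL, with an expected range of 16 ug/mL to 80 ug/mL.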

Compound 4, half-maximal cytotoxic concentration: 61.3 ug/mL
Estimate against measurement, compound 4: 1.7-fold (0.23 log units) below; measured number inside the range.
By their numbers in this assay, from the lowest: compounds 2, 1, 4 and 3 (each within the scatter of the next, the first and the last beyond it).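

Taking out one methyl is the smallest change measured at this position, and in this assay it stays within the scatter (a 1.9-fold higher number from compound 2 to compound 4 (0.27 log units; within the scatter)), so 3,5-dimethylphenyl and 3-methylphenyl are not separated here. Within the data shown here, compound 4 also stays within the scatter of both other compounds (a 1.3-fold lower number from compound 3 to compound 4 (0.12 log units; within the scatter); a 1.4-fold higher number from compound 1 to compound 4 (0.15 log units; within the scatter)), so it sits between compound 2 and compound 3, the one pair whose step lies beyond the scatter, and does not side clearly with either. Nothing available explains these numbers.

From the compounds shown here alone, it remains open whether an amine or a carboxylic acid in place of this methyl would give a step beyond the scatter from compound 2. Also open, going by these compounds, is what a plain phenyl, with hydrogen in place of both methyl groups, would give.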